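This account rests on a few compounds, and the source may have more. Where it says the series, first, only, none or still open, it means among the compounds named here.

Measured in a functional assay on MKN-45 cells (Homo sapiens) for cytotoxicity, read by MTT assay, with a stated time of 72 h; a lower number here means a stronger inhibitor, a higher number a weaker inhibitor:
Compound 1 `CN(C)CCn1cnnc1-c1cc(Oc2ccc(NC(=O)N/N=C/c3cccc(Cl)c3Cl)cc2F)ccn1` — 51 nM
Compound 2 `CN(C)CCn1cnnc1-c1cc(Oc2ccc(NC(=O)N/N=C/c3cc(C(C)(C)C)cc(C(C)(C)C)c3O)cc2F)ccn1` — 3300 nM

Compound 1 holds the lower of the two numbers, and compound 2 stands a long way behind it, well beyond the usual scatter of this assay. Among the measured compounds shown here, no single-change step between these two is available, so their values are simply two points on the same scale.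

Compound 3 `CN(C)CCn1cnnc1-c1cc(Oc2ccc(NC(=O)N/N=C/c3c(O)ccc4ccccc34)cc2F)ccn1` keeps the core of compound 1 and differs only at the aryl end of the hydrazone: 2-hydroxynaphthalen-1-yl in place of 2,3-dichlorophenyl on a carbon with a double bond to nitrogen. The entering group is larger than the one it replaces and brings a hydroxyl with it, where the leaving group carried none.

For the measured compounds named here, with no measured step of this kind, the direction can only be inferred from the two numbers at hand. The one other measured variation at this position, compound 2 with 3300 nM, shows that changes here can cost a great deal. Compound 3 is therefore expected to lose some potency against compound 1, with a step of a 5.9-fold higher number from compound 1 to compound 3 (0.77 log units; beyond the scatter), a moderate loss rather than a collapse. Compound 3 is estimated at 300 nM, within a range from 60 nM to 2000 nM.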

Compound 3, half-maximal inhibitory concentration: 2020 nM
Estimate against measurement, compound 3: 6.7-fold (0.83 log units) below; the whole stated range lies below it.
By their numbers in this assay, from the lowest: compound 1; then compounds 3 and 2 (each within the scatter of the next).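

In this assay, among the compounds shown here, the first single-change step at this position is a large one: replacing 2,3-dichlorophenyl with 2-hydroxynaphthalen-1-yl gives a 40-fold higher number from compound 1 to compound 3 (1.60 log units; beyond the scatter), so this position does not tolerate every aryl group equally. The value of compound 2 alone could not show whether its poor standing was particular to its own aryl group, but compound 3 at 2020 nM now lies within the usual scatter of compound 2 at 3300 nM, so two quite different hydroxyl-bearing aryl groups give values that cannot be told apart, both far from that of compound 1. No measurement at hand explains the loss from compound 1 to compound 3.

The change adds a second aromatic ring and a hydroxyl while removing both chlorines, and these compounds do not show which of these parts accounts for the step. A plain naphthalen-1-yl group, a 2-hydroxyphenyl group or a 3-chlorophenyl group on the same carbon would be the comparisons that could begin to separate them.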